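Phenyl Takes the Place of a Piperazine Arm

The source may report more compounds than this note shows. Statements on the series, on what has been measured and on what is new or still open speak of the compounds shown alone.

In a functional assay on the whole organism with Mus musculus as the target, in the rotarod test (a lower number here means that less compound is needed, a higher number that more compound is needed for the effect), compound 3 (`CN1CCN(CC(=O)NCC(=O)N(C)c2ccc(Cl)cc2C(=O)c2ccccc2Cl)CC1`) reaches only a limit (> 100 mg/kg). Compound 1 (`CN(C(=O)CNC(=O)CN1CCCCC1)c1ccc(Cl)cc1C(=O)c1ccccc1Cl`) also reaches only a limit (> 100 mg/kg), the same one (the limit of > 100 mg/kg in this assay, at which 2 of the 3 values shown sit). Compound 2 (`CC(=O)NCC(=O)N(C)c1ccc(Cl)cc1C(=O)c1ccccc1Cl`) gives a true number (58 mg/kg). Compound 4 (`CN(C(=O)CNC(=O)c1ccccc1)c1ccc(Cl)cc1C(=O)c1ccccc1Cl`) carries phenyl in place of (4-methylpiperazin-1-yl)methyl on a carbonyl carbon. Going by the values given here, two measured steps bear on this change (an at least 1.7-fold lower number from compound 1 to compound 2 (0.23 log units; that floor lies within the scatter) and an at least 1.7-fold higher number from compound 2 to compound 3 (0.23 log units; that floor lies within the scatter)). Both are floors within the scatter, so neither fixes a size. Compound 2 (58 mg/kg) also lacks the (4-methylpiperazin-1-yl)methyl group, so the estimate leans on it. A modest fall in this assay is expected (an at least 1.5-fold lower number from compound 3 to compound 4 (0.18 log units; that floor lies within the scatter)). Compound 4 is estimated at 65 mg/kg, with an expected range from 25 mg/kg to 170 mg/kg.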

Compound 4, dose for half-maximal effect: > 100 mg/kg
Compound 4 ended at the assay's limit; the forecaster's own chance of this, stated with the estimate: 35%; middle value at least 1.5-fold (0.18 log units) from the limit.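

Compound 4 shows that an arm without nitrogen, phenyl on the carbonyl carbon, also ends at a limit in this assay, so within these compounds a nitrogen-bearing ring is not needed to sit there: the limit of > 100 mg/kg in this assay, at which 3 of the 4 values shown sit.
Against the small methyl of compound 2, the one readable step has a floor within the scatter, so no real gap is shown: an at least 1.7-fold higher number from compound 2 to compound 4 (0.23 log units; that floor lies within the scatter).
The steps from compound 1 and compound 3 to compound 4 cannot be read, as both ends are limits.

On these data alone, how far compound 1, compound 3 and compound 4 lie from compound 2 stays open. So does whether a pyridin-3-yl ring or a dimethylaminomethyl group on that carbonyl carbon would give a true number.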